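A few compounds are considered here, and "the series" means these few. Any claim that something is new, unique, unknown or untested is made for them only; others in the source may bear on it.

Measured in a functional assay on NCI-H460 cells (Homo sapiens) for cytotoxicity, read by MTT assay, with a stated time of 48 h; on this read-out lower numbers stand for stronger inhibition and higher numbers for weaker inhibition:
- Compound 1 `C=C1C(=O)O[C@H]2CC3=C[C@H](C/C(C)=C/[C@@H](OC(=O)CCCCBr)[C@H]12)OC3=O`: > 10000 nM (a limit of the assay, not a number)
- Compound 2 `C=C1C(=O)O[C@H]2CC3=C[C@H](C/C(C)=C/[C@@H](OC(=O)C45CCC(C)(C(=O)O4)C5(C)C)[C@H]12)OC3=O`: 2000 nM

For the measured compounds named here, compound 2 holds the only true number so far. Compound 3 `C=C1C(=O)O[C@H]2CC3=C[C@H](C/C(C)=C/[C@@H](OC(=O)C(C)(C)CC)[C@H]12)OC3=O` changes one place on the shared core: a group of 5 heavy atoms (5 carbon; no ring) in place of a group of 11 heavy atoms (9 carbon, 2 oxygen; one five-membered non-aromatic ring of carbon only, one five-membered non-aromatic ring with 1 hetero atom), on a carbonyl carbon. The entering group is 1,1-dimethylpropyl. Going by the values given here, one measured step bears on this, an at least 5.0-fold lower number from compound 1 to compound 2 (0.69 log units; beyond the scatter), in which the same ring-bearing group replaced a small open chain. The change to compound 3 removes that group again, so a higher number is expected in this assay, of similar size to that step. The expected change is a 3.0-fold higher number from compound 2 to compound 3 (0.48 log units; beyond the scatter). For compound 3 the estimate is 6000 nM, with an expected range of 2000 nM to 18000 nM.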

Compound 3, half-maximal inhibitory concentration: 6100 nM
Compound 3: middle estimate off by 1.0-fold (0.01 log units), on the low side; the range from low to high includes it.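

In this assay, the group of 11 heavy atoms on this carbonyl carbon can now be compared with a true number rather than a limit, and 1,1-dimethylpropyl in its place gives a 3.1-fold higher number from compound 2 to compound 3 (0.48 log units; beyond the scatter). Open-chain 1,1-dimethylpropyl thus still gives a measurable value, while the two-ring group gives the lower number of the two. With 1,1-dimethylpropyl in place of 4-bromobutyl, the data give an at least 1.6-fold lower number from compound 1 to compound 3 (0.21 log units; that floor lies within the scatter). This comparison cannot be read beyond that floor, because it rests on a limit: the limit of > 10000 nM in this assay, at which 1 of the 3 values shown sits.

As far as these compounds go, it remains open how a chain ending in an amine or a carboxylic acid would behave on this carbonyl carbon. Also open, from the compounds shown here alone, is whether a single five-membered ring of carbon only would keep the lower number.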